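The source may report more compounds than this note shows. Statements on the series, on what has been measured and on what is new or still open speak of the compounds shown alone.

Measured so far in an ADME assay on HepG2 cells (Homo sapiens) for cytotoxicity, read by MTT assay, with a stated time of 72 h; a higher number here means a weaker inhibitor, a lower number a stronger inhibitor:

compound 1, `Cc1ccc(S(=O)(=O)Cc2nc(Nc3cccc(C(F)(F)F)c3)c3ccccc3n2)cc1`: > 25000 nM, which is a limit of the assay and not a number
compound 2, `Cc1ccc(S(=O)(=O)Cc2nc(Nc3ccc(F)cc3)c3ccccc3n2)cc1`: > 15000 nM, again a limit of the assay and not a number
compound 3, `Cc1ccc(S(=O)(=O)Cc2nc(Nc3cccc(C(F)(F)F)c3)c3cc([N+](=O)[O-])ccc3n2)cc1`: > 100000 nM, also a limit of the assay and not a number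

None of the three compounds gave a readable number in this assay. The change from compound 1 to compound 2 is 4-fluorophenyl in place of 3-(trifluoromethyl)phenyl on a nitrogen on an aromatic ring. The size of the step it made, a step that the two limits leave unreadable from compound 1 to compound 2, cannot be read because the limit of > 25000 nM in this assay, at which 1 of the 3 values shown sits, and the limit of > 15000 nM in this assay, at which 1 of the 3 values shown sits, are both limits. Compound 3 stands on a different core, which differs from the core of compound 1 by nitro in place of hydrogen on an aromatic carbon. The step that the two limits leave unreadable from compound 1 to compound 3 is likewise unreadable because the limit of > 25000 nM in this assay, at which 1 of the 3 values shown sits, and the limit of > 100000 nM in this assay, at which 1 of the 3 values shown sits, are both limits.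

Compound 4, `Cc1ccc(S(=O)(=O)Cc2nc(Nc3ccc(F)cc3)c3cc([N+](=O)[O-])ccc3n2)cc1`, is not yet measured. It differs from compound 3 by 4-fluorophenyl in place of 3-(trifluoromethyl)phenyl on a nitrogen on an aromatic ring. This is the same change as the one from compound 1 to compound 2, at the same place in both cases, and it occurs twice among these compounds. In this assay compound 4 is expected to make the step of a number no higher from compound 3 to compound 4 (the limit leaves the size open). For the measured compounds named here, that expectation rests on the step that the two limits leave unreadable from compound 1 to compound 2, which was too small to read against the limits, and on every compound so far sitting at a limit. The value estimated for compound 4 is 100000 nM, expected to lie between 30000 nM and 300000 nM, and most probably reported once more as a limit.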

Compound 4, half-maximal inhibitory concentration: > 50000 nM
Compound 4 ended at the assay's limit; the forecaster's own chance of this, stated with the estimate: 85%; the middle value does not contradict the limit.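

In this assay compound 4 gives > 50000 nM, which is a limit of the assay and not a number. Neither the step from compound 3 to compound 4 nor the step from compound 2 to compound 4 can be read, as each joins two limits. As far as these compounds go, with all four compounds at limits, the size of any effect of swapping 3-(trifluoromethyl)phenyl for 4-fluorophenyl, or of adding nitro, remains open.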